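Working notes: the step from compound 3 to compound 4

This account rests on a few compounds, and the source may have more. Where it says the series, first, only, none or still open, it means among the compounds named here.

Measured in an in vivo ADME assay on the whole organism (plasma, strain Sprague-Dawley) for pharmacokinetics, with Rattus norvegicus as the target; a lower number here means slower removal, a higher number faster removal of the compound:
Compound 1 `CN(C)C1CCc2cc(N3CC[C@H](NS(=O)(=O)/C=C/c4ccc(Cl)s4)C3=O)ccc21` gives 9.5 mL/min/kg
Compound 2 `CN(C)[C@@H]1CCc2cc(N3CC[C@H](NS(=O)(=O)c4ccc5cc(Cl)ccc5c4)C3=O)ccc21` gives 7.6 mL/min/kg
Compound 3 `CN1CCCC1c1ccc(N2CC[C@H](NS(=O)(=O)/C=C/c3ccc(Cl)s3)C2=O)c(F)c1` gives 11 mL/min/kg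

Compound 3 at 11 mL/min/kg sits within the scatter of both compound 1 and compound 2, so the three values are not separated in this assay. Compound 4 `O=C1[C@@H](NS(=O)(=O)/C=C/c2ccc(Cl)s2)CCN1c1ccc(C2CCCN2)cc1F` differs from compound 3 by hydrogen in place of methyl on an amine nitrogen in a ring. Within the data shown here, no measured pair shows this change, so the expectation rests only on the close values so far. The expected change, a 1.1-fold higher number from compound 3 to compound 4 (0.04 log units; within the scatter), stays within the scatter, with no firm direction. The estimate for compound 4 is 12 mL/min/kg in an expected range of 6 mL/min/kg to 25 mL/min/kg.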

Compound 4, clearance: 2.8 mL/min/kg
Estimate against measurement, compound 4: 4.3-fold (0.63 log units) above; the whole stated range lies above it.
By their numbers in this assay, from the lowest: compound 4; then compounds 2, 1 and 3 (each within the scatter of the next).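

In this assay, among these compounds, the change from 1-methylpyrrolidin-2-yl to pyrrolidin-2-yl gives a 3.9-fold lower number from compound 3 to compound 4 (0.59 log units; beyond the scatter) and is the only step so far beyond the scatter. Among the compounds shown here, this shows that the methyl on this amine nitrogen in a ring can matter on its own, which the close values of the earlier compounds could not reveal. No available data account for the step.

The finding rests on a single pair of compounds. From the compounds shown here alone, whether ethyl or acetyl on this nitrogen keeps the lower number remains open, as does whether the same change holds with the chloronaphthalene sulfonamide of compound 2 in place of the chlorothiophene vinyl sulfonamide.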